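Hydroxynaphthyl in place of chlorophenyl on the hydrazone carbon

The source may report more compounds than this note shows. Statements on the series, on what has been measured and on what is new or still open speak of the compounds shown alone.

Compound 2 `CCCSc1nc(N/N=C/c2cccc(Cl)c2)c2nnn(Cc3ccccc3)c2n1` was examined in a functional assay on MGC-803 cells (Homo sapiens) for antiproliferative activity, read by MTT assay, with a stated time of 72 h; a higher number here means a weaker inhibitor, a lower number a stronger inhibitor. In this assay compound 2 gives > 64000 nM, which is a limit of the assay and not a number. Among the compounds with values here, its only measured neighbour, compound 1 `CCCSc1nc(N/N=C/c2ccccc2F)c2nnn(Cc3ccccc3)c2n1`, differs from it at a single place. In this assay compound 1 gives > 64000 nM, again a limit rather than a number. Within the data shown here, the one step between them, a step that the two limits leave unreadable from compound 1 to compound 2, therefore has no readable size, and the limit of > 64000 nM in this assay, at which 2 of the 2 values shown sit, states that both values shown sit at that limit.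

Compound 3 `CCCSc1nc(N/N=C/c2c(O)ccc3ccccc23)c2nnn(Cc3ccccc3)c2n1` is not yet measured. It differs from compound 2 in one place: 2-hydroxynaphthalen-1-yl in place of 3-chlorophenyl on a carbon with a double bond to nitrogen. No measured step bears on this change in a readable way: the single step shown, a step that the two limits leave unreadable from compound 1 to compound 2, is unreadable, so nothing indicates a direction beyond the scatter. The expected step in this assay is an at least 1.6-fold lower number from compound 2 to compound 3 (0.20 log units; that floor lies within the scatter), with a real chance that only a limit is returned again. Compound 3 is estimated at 40000 nM, with a range from 8000 nM to 100000 nM.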

Compound 3, half-maximal inhibitory concentration: 3710 nM
The estimate for compound 3 lay 11-fold (1.03 log units) above the measured number; the measured number lies below the stated range.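

The carbon with a double bond to nitrogen proves to be a place where the attached group can bring a readable number in this assay, which neither 2-fluorophenyl nor 3-chlorophenyl had given. Putting 2-hydroxynaphthalen-1-yl there gives an at least 17-fold lower number from compound 2 to compound 3 (1.23 log units; beyond the scatter) and an at least 17-fold lower number from compound 1 to compound 3 (1.23 log units; beyond the scatter), and both sizes are floors, since each step starts from a limit of the assay and not from a number. The step between compound 1 and compound 2 cannot be read, so the two phenyl groups cannot be ranked against each other, and what the new result sets apart is the 2-hydroxynaphthalen-1-yl group from both of them: the limit of > 64000 nM in this assay, at which 2 of the 3 values shown sit.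

This one change brings in a hydroxyl and a second aromatic ring together, so the compounds shown do not tell which of the two accounts for the step, and a plain naphthalen-1-yl or a 2-hydroxyphenyl group on the same carbon would separate them. The rest of the structure is the same in compound 1, compound 2 and compound 3, which leaves open how the step would hold up with, for example, an amine in place of the sulfur-linked propyl chain.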